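Replacing the methoxyphenyl arm with a hexyl chain

This account rests on a few compounds, and the source may have more. Where it says the series, first, only, none or still open, it means among the compounds named here.

Compound 1 `Cc1ccc(-c2cc(/N=C3/NC(=O)CS3)cs2)cc1`: in a functional assay on HT-29 cells (Homo sapiens) for cytotoxicity, read by MTT assay, with a stated time of 72 h (a higher number here means a weaker inhibitor, a lower number a stronger inhibitor), compound 1 gives > 50000 nM, a limit of the assay and not a number.
Compound 2 `COc1ccc(-c2cc(/N=C3/NC(=O)CS3)cs2)cc1`: in this assay compound 2 gives > 50000 nM, likewise a limit.
Compound 3 `COc1ccc(/C=C2\S/C(=N\c3csc(-c4ccc(Cl)cc4)c3)NC2=O)cc1`: in this assay compound 3 gives 3800 nM.

Among the compounds with values here, compound 3 therefore holds the only number among the three values shown, the other two sitting at the limit of > 50000 nM in this assay, at which 2 of the 3 values shown sit. Within the data shown here, the sole step between measured compounds that differ in one place, a step that the two limits leave unreadable from compound 1 to compound 2, runs between two limits and cannot be read; it concerns methoxy in place of methyl on an aromatic carbon and says nothing about the position changed here.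

Compound 4 `CCCCCC/C=C1\S/C(=N\c2csc(-c3ccc(Cl)cc3)c2)NC1=O` has not yet been measured in this assay. It differs from compound 3 by hexyl in place of 4-methoxyphenyl on a double-bonded chain carbon bound to a double-bonded ring carbon. Among the measured compounds shown here, no measured step covers this exchange, and none of the three measured compounds carries a chain at that position, so the expectation rests on the structural change alone and is correspondingly loose. The step from compound 3 to compound 4 is expected to be a 2.4-fold higher number from compound 3 to compound 4 (0.37 log units; beyond the scatter), toward weaker inhibition. For compound 4 the estimate in this assay is 9000 nM, with a range from 2000 nM to 50000 nM.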

Compound 4, half-maximal inhibitory concentration: 33500 nM
Compound 4: the middle estimate sits 3.7-fold (0.57 log units) below what was measured; the measured number falls inside the stated range.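

Within the data shown here, with hexyl in place of 4-methoxyphenyl on a double-bonded chain carbon bound to a double-bonded ring carbon, the series gains its only readable step in this assay, an 8.8-fold higher number from compound 3 to compound 4 (0.95 log units; beyond the scatter), which lies beyond the scatter and runs toward weaker inhibition. Among these compounds, this shows that the group at this position matters to the read-out, something the earlier compounds could not show, as none of the comparisons among them concerned this place. Among the compounds shown here, it also shows that compound 4, with a chain and no ring at this position, still gives a number, while the one earlier step cannot be read, since both of its ends are limits and not numbers: the limit of > 50000 nM in this assay, at which 2 of the 4 values shown sit.

A single exchange cannot separate the loss of the aromatic ring from the loss of the methoxy oxygen, a question that a plain phenyl or a cyclohexyl group at the same place would bear on. On these data alone, how the value depends on chain length, or on a chain ending in an amine or a carboxylic acid, also stays open.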